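This account rests on a few compounds, and the source may have more. Where it says the series, first, only, none or still open, it means among the compounds named here.

Compound 1 `COc1ccc(C(=O)NCc2ccc(CNS(=O)(=O)c3ccccc3)cc2)cc1` stands at the higher of the two numbers recorded so far in an assay on MDA-MB-231 cells for binding affinity to C-X-C chemokine receptor type 4 (Homo sapiens), read by immunofluorescence and microscopy, with stated times of 10 min and 30 min (a lower number here means that less compound is needed, a higher number that more compound is needed for the effect), where compound 1 gives 1000 nM. Within the data shown here, compound 2 `Cc1ccc(S(=O)(=O)NCc2ccc(CNC(=O)c3cccc(Cl)c3)cc2)cc1` differs from compound 1 in several places, and no single step connects these two compounds; in this assay compound 2 gives 100 nM, a lower number than that of compound 1 by a margin beyond the usual scatter. Compound 3 `Cc1cccc(C(=O)NCc2ccc(CNS(=O)(=O)c3ccccc3)cc2)c1` has not yet been measured. It differs from compound 1 in one place: 3-methylphenyl in place of 4-methoxyphenyl on a carbonyl carbon. Among the measured compounds shown here, no measured pair isolates this change, so its size cannot be read off and only an expectation can be given. Compound 3 is expected to move modestly toward a lower number, with the step from compound 1 estimated as a 2.0-fold lower number from compound 1 to compound 3 (0.30 log units; within the scatter). Compound 3 is therefore estimated at 500 nM in this assay, within a range of 150 nM to 2000 nM.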

Compound 3, effective concentration (reported as EC, without a stated level of effect): 1000 nM
Beside the measured number, compound 3's estimate is 2.0-fold (0.30 log units) below it; measured number inside the range.
By their numbers in this assay, from the lowest: compound 2; then compounds 1 and 3 (each within the scatter of the next).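

Exchanging 4-methoxyphenyl for 3-methylphenyl on a carbonyl carbon gives no change at the digits printed from compound 1 to compound 3 (within the scatter) in this assay. Among these compounds, this is the first pair to isolate a change at this position, and it shows that the exchange, which removes the hydrogen-bond acceptor counted in 4-methoxyphenyl, leaves the number within the scatter. No evidence on the cause accompanies this result.

The two groups differ in both the substituent and its numbered place on the ring, so this pair leaves open whether either difference alone would matter, or whether the two simply happen to give matching numbers. It also leaves open what an amine or a carboxylic acid on this ring, or a longer chain in place of the ring, would do on this carbonyl carbon.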